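The source may hold more compounds than are shown below. What is called first, only, known or untested is meant among the compounds shown, and "the series" means these compounds.

In an ADME assay on microsomes from liver (Homo sapiens) for metabolic stability (a lower number here means slower removal, a higher number faster removal of the compound), compound 1 `COc1ncc(-c2cc3c(C)nc(N)nc3n([C@H]3CC[C@@H](OCO)CC3)c2=O)cc1F` gives 142 mL.min-1.g-1 and compound 3 `Cc1nc(N)nc2c1cc(-c1cnc3ccccc3c1)c(=O)n2[C@H]1CC[C@@H](OCO)CC1` gives 105 mL.min-1.g-1 while the step of a 1.4-fold lower number from compound 1 to compound 3 (0.13 log units; within the scatter) does not separate them, so the two sit together at the top of the three numbers. Compound 2 `Cc1nc(N)nc2c1cc(-c1cn[nH]c1)c(=O)n2[C@H]1CC[C@@H](OCO)CC1` stands apart at 23.4 mL.min-1.g-1 as the steps of a 6.1-fold lower number from compound 1 to compound 2 (0.78 log units; beyond the scatter) and a 4.5-fold higher number from compound 2 to compound 3 (0.65 log units; beyond the scatter) show.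

The next compound keeps every atom and bond of compound 1. In compound 4 `COc1ncc(-c2cc3c(C)nc(N)nc3n([C@H]3CC[C@H](OCO)CC3)c2=O)cc1F` the change is this: the two compounds have the same atoms and bonds and differ only in configuration as drawn: 2 of 2 stereo elements differ (all stereocentres are inverted: mirror images); a stereocentre at a saturated ring carbon is drawn s in compound 1 and r in compound 4; a stereocentre at a saturated ring carbon is drawn s in compound 1 and r in compound 4 and it lies at the saturated ring carbons. All three measured steps exchange the aromatic group on the shared core, and that group stays the same here. None of those steps tests configuration, so they offer no size or direction for this change. Going by the values given here, no pair differing only in configuration has been measured, so no shift beyond the scatter can be argued in this assay and the range has to stay wide. The step expected is a 1.2-fold lower number from compound 1 to compound 4 (0.07 log units; within the scatter) and thus no real change. For compound 4 the estimated value is 120 mL.min-1.g-1 with an expected range from 55 mL.min-1.g-1 to 240 mL.min-1.g-1 as the likely span.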

Compound 4, intrinsic clearance in microsomes: < 8 mL.min-1.g-1
Compound 4 was reported as a limit (the forecaster's own chance of this, stated with the estimate: 5%); middle value at least 15-fold (1.17 log units) away from the limit.
By their numbers in this assay, from the lowest: compound 2; then compounds 3 and 1 (each within the scatter of the next). At a limit, below all of these: compound 4.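

In this assay, going by these compounds alone, the inversion of both stereocentres at the saturated ring carbons gives an at least 17-fold lower number from compound 1 to compound 4 (1.24 log units; beyond the scatter), a larger step than any among the earlier compounds, whose steps all exchange the aromatic group. The whole step belongs to configuration alone: the fact that compounds 1 and 4 differ only in the configuration as drawn The number for compound 4 is a limit and not a measured value: the limit of < 8 mL.min-1.g-1 in this assay, at which 1 of the 4 values shown sits.

The compounds shown leave open whether the same inversion would move the number as far with the 1H-pyrazol-4-yl group of compound 2 or the quinolin-3-yl group of compound 3. They also leave open how much the configuration would count if an amine or a carboxylic acid stood on the saturated ring in place of the present substituent.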